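The source may hold more compounds than are shown below. What is called first, only, known or untested is meant among the compounds shown, and "the series" means these compounds.

Within the data shown here, compound 1, whose structure is `COc1cc(-c2nnc3n2NC(c2ccco2)C(C(=O)c2cccc(Br)c2)S3)cc(OC)c1OC`, is the one member of this small set with a numerical result: in a functional assay on A549 cells (Homo sapiens) for cytotoxicity, read by MTT assay, with a stated time of 48 h (on this read-out higher numbers stand for weaker inhibition and lower numbers for stronger inhibition), compound 1 gives 36900 nM. Compound 2, with structure `COc1ccc(C(=O)C2Sc3nnc(-c4cc(OC)c(OC)c(OC)c4)n3NC2c2cccs2)cc1`, gives only a limit in this assay, namely > 100000 nM. That result is described by the limit of > 100000 nM in this assay, at which 1 of the 2 values shown sits, so compound 1 stands as the only point that can be placed on the scale at all. Compound 3, with structure `COc1cc(-c2nnc3n2NC(c2ccco2)C(C(=O)c2ccc(O)cc2)S3)cc(OC)c1OC`, has not yet been measured in this assay. It is derived from compound 1 by a single exchange on the carbonyl carbon whose other neighbour is a saturated ring carbon: 4-hydroxyphenyl in place of 3-bromophenyl on a carbonyl carbon. Among the measured compounds shown here, no measured pair in this set shares that exchange, so the size of its effect cannot be read from the data. Given that compound 1 itself gives 36900 nM, the step from compound 1 to compound 3 is expected to be small and to stay within the scatter, a 1.2-fold higher number from compound 1 to compound 3 (0.09 log units; within the scatter). For compound 3 the estimate in this assay is therefore 45000 nM, with a range from 15000 nM to 140000 nM.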

Compound 3, half-maximal inhibitory concentration: 93400 nM
Compound 3: middle estimate off by 2.1-fold (0.32 log units), on the low side, and the stated range covers the measured number.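

In this assay, among these compounds, 4-hydroxyphenyl in place of 3-bromophenyl on a carbonyl carbon gives a 2.5-fold higher number from compound 1 to compound 3 (0.40 log units; beyond the scatter), the first step in this set that can be read at all. The step is modest but beyond the scatter, so the group on this carbonyl carbon, whose other neighbour is a saturated ring carbon, does affect the read-out, and this exchange moves it toward weaker inhibition. Nothing shown here offers an explanation for the step.

Among the compounds shown here, the single exchange leaves open whether the shift follows from the loss of the 3-bromophenyl pattern or from the arrival of the 4-hydroxyphenyl pattern, a question that 4-bromophenyl or 3-hydroxyphenyl on the same carbonyl carbon would help to separate, while compound 2, whose result is only a limit, differs from the other compounds in more than one place and adds no step. Also open, from the compounds shown here alone, is how the same ring carrying an amine or a carboxylic acid would read in this assay on the core of compound 1.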